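Swapping the amide for a fluorinated diol on the core

A few compounds are considered here, and "the series" means these few. Any claim that something is new, unique, unknown or untested is made for them only; others in the source may bear on it.

Three compounds share a core built from the structure of compound 1 `CC#C[C@H]1CN(S(=O)(=O)c2ccc(N)nc2)CCN1c1ccc(S(N)(=O)=O)cc1` and differ only in the group carried on the aromatic ring at its far end. In an assay on cells (Hepatocyte) for inhibition of glucokinase regulatory protein (Mus musculus), with stated times of 20 min and 40 min (on this read-out higher numbers stand for an effect only at larger amounts of compound and lower numbers for an effect already at smaller amounts), compound 1 gives 37 nM. Compound 2 `CC#CCC(O)(c1ccc(N2CCN(S(=O)(=O)c3ccc(N)nc3)C[C@@H]2C#CC)cc1)C(F)(F)F` carries a hydroxy-bearing, trifluoromethyl-bearing chain there, and in this assay compound 2 gives 137 nM, a change of a 3.7-fold higher number from compound 1 to compound 2 (0.57 log units; beyond the scatter). Compound 3 `CC#C[C@H]1CN(S(=O)(=O)c2ccc(N)nc2)CCN1c1ccc(C(=O)NC)cc1` carries a methylcarbamoyl group, and in this assay compound 3 gives 4050 nM, the highest number of the three, after a change of a 110-fold higher number from compound 1 to compound 3 (2.04 log units; beyond the scatter) and of a 30-fold higher number from compound 2 to compound 3 (1.47 log units; beyond the scatter).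

Compound 4 `CC#C[C@H]1CN(S(=O)(=O)c2ccc(N)nc2)CCN1c1ccc([C@](O)(CO)C(F)(F)F)cc1` is the next step from compound 3: 1,2-dihydroxy-1-(trifluoromethyl)ethyl in place of methylcarbamoyl on an aromatic carbon. The entering group resembles the chain in compound 2 in its hydroxy and trifluoromethyl parts, so the most relevant comparison is the step of a 30-fold higher number from compound 2 to compound 3 (1.47 log units; beyond the scatter), which ran the other way. Reversing most of that step, a large drop in this assay is expected, with compound 4 landing close to compound 2 rather than to compound 3. Compound 4 is therefore estimated at 110 nM, within a range from 30 nM to 450 nM, an expected step of a 37-fold lower number from compound 3 to compound 4 (1.57 log units; beyond the scatter).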

Compound 4, half-maximal effective concentration: 98 nM
Estimate against measurement, compound 4: 1.1-fold (0.05 log units) above; measured number inside the range.
By their numbers in this assay, from the lowest: compound 1; then compounds 4 and 2 (each within the scatter of the next); then compound 3.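

The a 41-fold lower number from compound 3 to compound 4 (1.62 log units; beyond the scatter) in this assay shows that the high number of compound 3 belongs to methylcarbamoyl and not to the shared core, since a different group on the same aromatic carbon recovers most of the lost ground. The a 1.4-fold lower number from compound 2 to compound 4 (0.15 log units; within the scatter) shows that two different chains carrying hydroxy and trifluoromethyl cannot be told apart here, so this position accepts a change in what surrounds those two parts, at least across these two compounds. Sulfamoyl still keeps its lead, as a 2.6-fold higher number from compound 1 to compound 4 (0.42 log units; beyond the scatter) stays beyond the scatter and compound 1 has the lowest number of all four compounds.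

The compounds shown leave open whether a plain hydroxymethyl group without trifluoromethyl, or a carboxylic acid on this aromatic carbon, would stay near compound 4, and what the opposite arrangement at the defined stereocentre would give. Nothing measured here explains why these groups differ in this way.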